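The source may report more compounds than this note shows. Statements on the series, on what has been measured and on what is new or still open speak of the compounds shown alone.

Compound 1 `O=C1CSC(c2ccc(O)cc2)N1CCN1CCCCC1` gives 94% in an ADME assay on Vero cells (Chlorocebus sabaeus) for cytotoxicity, read by neutral red uptake, tested at 98 ug/mL; a higher number here means a weaker effect of the compound at the concentration tested, a lower number a stronger effect.
Compound 2 `O=C1CSC(c2ccc([N+](=O)[O-])cc2)N1CCN1CCCCC1` gives 87% in this assay.
Compound 3 `Cc1ccc(C2SCC(=O)N2CCN2CCCCC2)cc1` gives 100% in this assay.

All three compounds share one core and differ only in the group on the aromatic ring. Compound 3 has the highest of the three numbers in this assay, meaning the weakest effect at the concentration tested. Its nearest neighbour is compound 1, with a number 6 percentage points higher from compound 1 to compound 3 (within the scatter); its furthest is compound 2, with a number 13 percentage points higher from compound 2 to compound 3 (beyond the scatter). The remaining step, a number 7 percentage points lower from compound 1 to compound 2 (within the scatter), is small as well.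

Compound 4 `O=C1CSC(c2cccc(F)c2)N1CCN1CCCCC1` is the next compound. Relative to compound 3 the change is 3-fluorophenyl in place of 4-methylphenyl on a saturated ring carbon.

Among the compounds with values here, no measured step swaps the whole aryl group, and none places a fluorine, so no step bears directly on this change. Within the data shown here, what the three steps do show is that three different groups on the aromatic carbon all leave the number in this assay high, with only one step beyond the scatter. The expected step is therefore a number 5 percentage points lower from compound 3 to compound 4 (within the scatter), within the scatter. Compound 4 is expected to give about 95% in this assay, most likely between 84% and 100%.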

Compound 4, a percentage reported as activity, at one concentration (the size of the read-out at that concentration, not a potency): 92%
Compound 4: the middle estimate sits 3 percentage points above what was measured; the measured number falls inside the stated range.
By their numbers in this assay, from the lowest: compounds 2, 4, 1 and 3 (each within the scatter of the next, the first and the last beyond it).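

In this assay, replacing the whole aryl group on this saturated ring carbon gives a number 8 percentage points lower from compound 3 to compound 4 (within the scatter) and the replacement of 4-hydroxyphenyl by 3-fluorophenyl gives a number 2 percentage points lower from compound 1 to compound 4 (within the scatter). The earlier steps shown here changed only the group on an aromatic carbon, whereas compound 4 brings in a fluorine and also a different place for the group on the phenyl ring, and neither of these two steps lies beyond the usual scatter. No measurement shown here explains why these replacements have so small an effect on the number.

All four compounds carry a phenyl ring with one added group on this ring carbon, so the result says nothing about whether an amine or a carboxylic acid on that ring would keep the number in the same range, or whether a cyclohexyl group or a longer chain could take the place of the phenyl ring. The read-out also comes from one concentration, so it cannot show how these compounds would behave at higher concentrations.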